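Dropping the chloro from a weakly cytotoxic phenol

A few compounds are considered here, and "the series" means these few. Any claim that something is new, unique, unknown or untested is made for them only; others in the source may bear on it.

Within the data shown here, compound 2 `COCc1cc(O)cc(Cl)c1O` is one of two compounds measured in a functional assay on A549 cells (Homo sapiens) for cytotoxicity, read by sulforhodamine B assay (a lower number here means a stronger inhibitor, a higher number a weaker inhibitor), the other being compound 1 `COCc1cc(O)c(Cc2cc(O)ccc2O)cc1O`. In this assay compound 2 gives 56500 nM, and compound 1 gives 33800 nM; the number for compound 2 is the higher of the two, but the gap lies within the usual scatter, so the pair cannot be separated. Compound 3 `COCc1cc(O)ccc1O` differs from compound 2 by hydrogen in place of chloro on an aromatic carbon. Among the measured compounds shown here, no comparable step is on record, so a shift beyond the scatter is not expected, with any drift leaning toward a weaker number. Compound 3 is estimated at 80000 nM, between 30000 nM and 250000 nM, a step of a 1.4-fold higher number from compound 2 to compound 3 (0.15 log units; within the scatter).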

Compound 3, half-maximal inhibitory concentration: > 100000 nM
Compound 3: only a limit was reported; the forecaster's own chance of this, stated with the estimate: 25%; middle value at least 1.2-fold (0.09 log units) from the limit.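

In this assay compound 3 gives > 100000 nM as a limit of the assay, not a number. At this aromatic carbon, ortho to a hydroxy group, hydrogen in place of chloro amounts to an at least 1.7-fold higher number from compound 2 to compound 3 (0.24 log units; that floor lies within the scatter) as a floor only, so the change brings no gain in this assay. How far the number really moves stays hidden behind the limit: the limit of > 100000 nM in this assay, at which 1 of the 3 values shown sits.

The compounds shown leave open whether another group on this carbon, such as bromo, methyl or an amine, would move the number beyond the scatter. They also leave open whether chloro would count the same way on the core of compound 1.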